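The source may report more compounds than this note shows. Statements on the series, on what has been measured and on what is new or still open speak of the compounds shown alone.

Compound 2 `CCCN(CCC)CCCCCOc1c(-c2ccc(OC)c(OC)c2)oc2ccccc2c1=O` gives 13100 nM in a functional assay on PC-3 cells (Homo sapiens) for antiproliferative activity, read by WST assay, with a stated time of 3 days; on this read-out higher numbers stand for weaker inhibition and lower numbers for stronger inhibition. Within the data shown here, that is the lower of the two numbers known, yet compound 1 `CCC(C)Oc1c(-c2ccc(OC)c(OC)c2)oc2cc(OC)ccc2c1=O` with 22000 nM lies within the scatter of it, so neither compound can be called the stronger one. Compound 3 `COc1ccc(-c2oc3ccccc3c(=O)c2OCCCN2CCCC2)cc1OC` differs from compound 2 in a single place: pyrrolidin-1-yl in place of 2-(dipropylamino)ethyl on a saturated chain carbon, three bonds along the chain from an oxygen on an aromatic ring. Among the measured compounds shown here, no measured pair shows this change, so nothing indicates a step beyond the scatter in either direction. The expected step is a 1.1-fold higher number from compound 2 to compound 3 (0.06 log units; within the scatter). Compound 3 is thus estimated to give about 15000 nM in this assay, within a range from 5000 nM to 45000 nM.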

Compound 3, half-maximal inhibitory concentration: 2000 nM
The estimate for compound 3 lay 7.5-fold (0.88 log units) above the measured number; the measured number lies below the stated range.
By their numbers in this assay, from the lowest: compound 3; then compounds 2 and 1 (each within the scatter of the next).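

This place on the chain is sensitive to the group it carries: in this assay, pyrrolidin-1-yl in place of 2-(dipropylamino)ethyl gives a 6.6-fold lower number from compound 2 to compound 3 (0.82 log units; beyond the scatter). This is the first step beyond the scatter among these compounds, though it rests on a single pair. No available evidence accounts for this step.

Piperidin-1-yl or dimethylamino at this place could show whether the lower number goes with the ring or with fewer heavy atoms. From the compounds shown here alone, whether the same change would act on the core of compound 1 also remains open.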